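A few compounds are considered here, and "the series" means these few. Any claim that something is new, unique, unknown or untested is made for them only; others in the source may bear on it.

Measured so far in an ADME assay on Akata cells (Homo sapiens) for cytotoxicity, with a stated time of 7 days; a higher number here means that more compound is tolerated, a lower number that less compound is tolerated:

compound 1 `C=CCOc1nc(N)nc2c1ncn2/C=C1/CC1(CO)CO` gives > 20000 nM, a limit of the assay.
compound 2 `CC(C)Nc1nc(N)nc2c1ncn2/C=C1/CC1(CO)CO` gives > 24000 nM, a limit of the assay.
compound 3 `CCCCCCCCSc1nc(N)nc2c1ncn2/C=C1/CC1(CO)CO` gives > 20000 nM, a limit of the assay.

Compound 3 stands only at a limit in this assay, as do the two other measured compounds, so no order among the three can be read. The step to compound 4 `CCCCCCOc1nc(N)nc2c1ncn2/C=C1/CC1(CO)CO` is hexyloxy in place of octylsulfanyl on an aromatic carbon. For the measured compounds named here, the steps that bear on it, a step that the two limits leave unreadable from compound 1 to compound 3 and a step that the two limits leave unreadable from compound 2 to compound 3, are both unreadable, each resting on the limit of > 20000 nM in this assay, at which 2 of the 3 values shown sit, or (the limit of > 24000 nM in this assay, at which 1 of the 3 values shown sits). No direction or size can be drawn from them, and the expectation is that compound 4 also sits at a limit. Compound 4 is therefore estimated at 20000 nM, within 10000 nM to 60000 nM, an expected step of a number no higher from compound 3 to compound 4 (the limit leaves the size open).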

Compound 4, half-maximal cytotoxic concentration: > 20000 nM
Compound 4 was reported as a limit; the forecaster's own chance of this, stated with the estimate: 85%; the middle value lies on the limit itself.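

For the compounds shown here, compound 4 stands at a limit in this assay, as do compound 1, compound 2 and compound 3, so no step to compound 4 can be read. The compounds shown leave open the actual half-maximal cytotoxic concentration of all four.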